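The compounds below may be only part of what the source reports. "The series", "measured", "known", "first", "only" and "open" are said of these compounds alone.

In a functional assay on MIA PaCa-2 cells (Homo sapiens) for antiproliferative activity, read by MTT assay, with a stated time of 24 h (a higher number here means a weaker inhibitor, a lower number a stronger inhibitor), compound 2 (`COc1ccc(-c2noc(C3CCNCC3)n2)cc1OC1CCCC1`) gives 540 nM, the lower of the two actual numbers available. Compound 1 (`c1ccc(-c2noc(-c3ccncc3)n2)cc1`) gives 497000 nM, a gap well beyond the scatter from compound 2. Compound 3 (`Fc1ccc(-c2nc(-c3ccccc3)no2)cc1`) reads > 1000000 nM, which is a limit of the assay and not a number.

Compound 4 (`COc1ccc(-c2noc(-c3ccc(Cl)cc3)n2)cc1OC1CCCC1`) keeps the rest of compound 2 but carries 4-chlorophenyl in place of piperidin-4-yl on an aromatic carbon. Within the data shown here, no measured pair isolates this change, so the expectation rests on a loose comparison. Neither compound 3 nor compound 1 carries piperidin-4-yl, and compound 1 sits at 497000 nM, which points towards a weaker inhibitor in this assay. Compound 4 retains the remainder of compound 2, however, so it is not expected to fall as far. The expected change, beyond the scatter and upward, is a 19-fold higher number from compound 2 to compound 4 (1.27 log units; beyond the scatter). For compound 4 the estimated value is 10000 nM, with an expected range from 800 nM to 150000 nM.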

Compound 4, half-maximal inhibitory concentration: 740 nM
Beside the measured number, compound 4's estimate is 14-fold (1.13 log units) above it, outside the stated range (below it).
By their numbers in this assay, from the lowest: compounds 2 and 4 (each within the scatter of the next); then compound 1. At a limit, above all of these: compound 3.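

Replacing piperidin-4-yl with 4-chlorophenyl on this aromatic carbon gives a 1.4-fold higher number from compound 2 to compound 4 (0.14 log units; within the scatter) in this assay. Among these compounds, this pair is the first in which only this position differs, and it shows that the non-aromatic ring with its nitrogen can give way to a carbon-only aromatic ring without a change beyond the scatter, even though the entering group has no hydrogen-bond donor or acceptor. Nothing measured here accounts for this result.

The compounds shown leave open how this position would respond to a carboxylic acid or an open-chain amine, which would test it with groups unlike both of those compared here. Also open, from the compounds shown here alone, is what the chlorine of 4-chlorophenyl contributes, and whether the same replacement would read alike on a different remainder of the molecule.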